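The source may report more compounds than this note shows. Statements on the series, on what has been measured and on what is new or still open speak of the compounds shown alone.

The half-lives measured so far in an ADME assay on microsomes (Homo sapiens) for metabolic stability (on this read-out higher numbers stand for a longer-lived compound and lower numbers for a shorter-lived compound), are these:
compound 1 `O=C(C1CCCC1)N1N=CCC1c1ccccc1` gives 1.13 h
compound 2 `CC(C)(C)C(=O)N1N=CCC1c1cocn1` gives > 1.5 h (a limit of the assay, not a number)
compound 3 `CC(C)(C)C(=O)N1N=CCC1C1CCCC1` gives 0.0983 h

Of the two exact numbers, compound 1 holds the higher (1.13 h), and compound 3 gives 0.0983 h, a gap beyond the scatter. Compound 4 `O=C(C1CCOCC1)N1N=CCC1c1ccccc1` differs from compound 1 in one place (oxan-4-yl in place of cyclopentyl on a carbonyl carbon), with oxan-4-yl in place of cyclopentyl on a carbonyl carbon. Among the compounds with values here, only one measured step bears on this, and only indirectly. In an at least 15-fold lower number from compound 2 to compound 3 (1.18 log units; beyond the scatter) cyclopentyl entered in place of 1,3-oxazol-4-yl on a saturated ring carbon, so that large drop concerns another place and another partner group. It suggests that a rise in this assay may follow when cyclopentyl leaves, though a far smaller one than that drop. The expected change is a 1.8-fold higher number from compound 1 to compound 4 (0.25 log units; within the scatter) and points upward, without a step beyond the scatter being firmly expected. Compound 4 is estimated at 2 h (expected range 1 h to 4.5 h).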

Compound 4, half-life: > 1.5 h
Compound 4 gave a limit, no number; the forecaster's own chance of this, stated with the estimate: 50%; the middle value is on the limit's open side.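

In this assay, oxan-4-yl in place of cyclopentyl on a carbonyl carbon gives an at least 1.3-fold higher number from compound 1 to compound 4 (0.12 log units; that floor lies within the scatter). This is the first step at this place among the compounds shown, and it shows that the exchange brings no loss of half-life, although its floor alone does not establish a gain. The true size of the step cannot be read, because the read-out of compound 4 ends at a limit: the limit of > 1.5 h in this assay, at which 2 of the 4 values shown sit.

The compounds shown leave open how long the half-life of compound 4 really is, and whether the same exchange would behave alike on a core carrying another group on the saturated ring carbon. Also open, from the compounds shown here alone, is whether a piperidin-4-yl amine or an open methoxyethyl chain on the same carbonyl carbon would match oxan-4-yl.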